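This account rests on a few compounds, and the source may have more. Where it says the series, first, only, none or still open, it means among the compounds named here.

Measured in a functional assay on SW-620 cells (Homo sapiens) for cytotoxicity, read by MTT assay, with stated times of 4 h and 72 h, tested at 5 uM; a lower number here means a stronger inhibitor, a higher number a weaker inhibitor:
- compound 1 `Cc1cc(Nc2ccc(C(=O)/C=C/c3ccc4ccccc4c3)cc2)n2nc(SCc3cccc([N+](=O)[O-])c3)nc2n1`: 790 nM
- compound 2 `Cc1cc(Nc2ccc(C(=O)/C=C/c3ccc4ccccc4c3)cc2)n2nc(SCc3ccccc3C(F)(F)F)nc2n1`: 1240 nM
- compound 3 `Cc1cc(Nc2ccc(C(=O)/C=C/c3ccc4ccccc4c3)cc2)n2nc(SCc3ccc(F)cc3)nc2n1`: 320 nM

Compound 3 has the lowest number of the three, and its steps to both others lie beyond the scatter. Compound 4 `Cc1cc(Nc2ccc(C(=O)/C=C/c3ccc4ccccc4c3)cc2)n2nc(SCc3ccccc3Br)nc2n1` differs from it in one place: 2-bromophenyl in place of 4-fluorophenyl on a saturated chain carbon bound to a sulfur. Among the measured compounds shown here, two measured steps bear on this change, a 2.5-fold lower number from compound 1 to compound 3 (0.39 log units; beyond the scatter) and a 3.9-fold lower number from compound 2 to compound 3 (0.59 log units; beyond the scatter). The second is the nearer guide, since 2-(trifluoromethyl)phenyl is the closest match by name to 2-bromophenyl. Run backwards, it points to a higher number in this assay, though the bromine-bearing group has not been tested here. The expected change is a 2.5-fold higher number from compound 3 to compound 4 (0.40 log units; beyond the scatter), somewhat smaller than that guide. For compound 4 the estimated value is 800 nM, with an expected range of 350 nM to 1800 nM.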

Compound 4, half-maximal inhibitory concentration: 420 nM
For compound 4 the middle estimate is 1.9-fold (0.28 log units) above the measured one; low and high end bracket the measured number.
By their numbers in this assay, from the lowest: compounds 3, 4, 1 and 2 (each within the scatter of the next, the first and the last beyond it).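

Putting 2-bromophenyl in place of 4-fluorophenyl on a saturated chain carbon bound to a sulfur gives no clear change in this assay: a 1.3-fold higher number from compound 3 to compound 4 (0.12 log units; within the scatter). The groups 2-(trifluoromethyl)phenyl and 2-bromophenyl do not behave alike, with bromo in place of trifluoromethyl giving a 3.0-fold lower number from compound 2 to compound 4 (0.47 log units; beyond the scatter), while the swap from 3-nitrophenyl gives a 1.9-fold lower number from compound 1 to compound 4 (0.27 log units; within the scatter). Nothing available explains these differences. From the compounds shown here alone, whether an amine or a carboxylic acid on this ring, or a longer chain to the sulfur, would hold these numbers stays open.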